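A few compounds are considered here, and "the series" means these few. Any claim that something is new, unique, unknown or untested is made for them only; others in the source may bear on it.

Compound 1 `CN1CC[C@H](c2c(O)cc(O)c3c(=O)cc(/C=C/c4ccccc4)oc23)[C@H](O)C1` and compound 2 `CN1CC[C@H](c2c(O)cc(O)c3c(=O)cc(/C=C/c4c(F)c(F)c(F)c(F)c4F)oc23)[C@H](O)C1` share one core and differ only in the group on a double-bonded chain carbon. In a functional assay on HL-60 cells (Homo sapiens) for inhibition, read by MTT assay, with a stated time of 48 h (on this read-out lower numbers stand for stronger inhibition of growth and higher numbers for weaker inhibition of growth), compound 1 gives 1000 nM and compound 2 gives 3000 nM, so compound 2 holds the higher of the two numbers and inhibits growth more weakly. Compound 3 `CN1CC[C@H](c2c(O)cc(O)c3c(=O)cc(/C=C/c4cccc(F)c4)oc23)[C@H](O)C1` changes that same place, with 3-fluorophenyl in place of 2,3,4,5,6-pentafluorophenyl on a double-bonded chain carbon bound to a double-bonded chain carbon. Among the measured compounds shown here, only one measured step bears on this change: a 3.0-fold higher number from compound 1 to compound 2 (0.48 log units; beyond the scatter), where phenyl gave way to 2,3,4,5,6-pentafluorophenyl. Since 3-fluorophenyl stands closer to the phenyl of compound 1, most of that modest step is expected to reverse. For the measured compounds named here, no measured compound yet carries 3-fluorophenyl, so this expectation remains loose. The expected change is a 2.3-fold lower number from compound 2 to compound 3 (0.36 log units; beyond the scatter), towards stronger inhibition of growth. For compound 3 the estimate is 1300 nM, with an expected range of 600 nM to 3000 nM.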

Compound 3, concentration for 50% growth inhibition: 8000 nM
The estimate for compound 3 lay 6.2-fold (0.79 log units) below the measured number; measured number outside the range, above it.
By their numbers in this assay, from the lowest: compound 1; then compound 2; then compound 3.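

Fluoro in place of hydrogen on an aromatic carbon brings an 8.0-fold higher number from compound 1 to compound 3 (0.90 log units; beyond the scatter) and so weakens growth inhibition further than the pentafluorophenyl group of compound 2 does. Replacing 2,3,4,5,6-pentafluorophenyl with 3-fluorophenyl brings a 2.7-fold higher number from compound 2 to compound 3 (0.43 log units; beyond the scatter) and shows that, across these three compounds, the number does not simply climb with the count of fluorines: compound 1 sits lowest, compound 2 in the middle and compound 3 highest. Nothing available here explains this order.

The compounds shown leave open whether a chloro or a methoxy group in place of the fluoro of compound 3 would give a number nearer to compound 1 or to compound 3. They also leave open how an amine or a carboxylic acid on that ring would read.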